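Cytotoxicity notes: imine analogue with nitrophenyl group

The compounds below may be only part of what the source reports. "The series", "measured", "known", "first", "only" and "open" are said of these compounds alone.

Measured so far in an ADME assay on HepG2 cells (Homo sapiens) for cytotoxicity, read by MTT assay, with a stated time of 72 h; a lower number here means that less compound is tolerated, a higher number that more compound is tolerated:
compound 1 `Nc1sc2c(c1-c1nc3cc(Cl)ccc3s1)CCC2` gives 67.8 ug/mL
compound 2 `Nc1sc2c(c1-c1nc3cc(Cl)ccc3s1)CCCC2` gives 93.7 ug/mL
compound 3 `Clc1ccc(/C=N/c2sc3c(c2-c2nc4ccccc4s2)CCCC3)c(Cl)c1` gives 384 ug/mL

Compound 3 stands highest of the three numbers in this assay. Its nearest neighbour is compound 2, whose number is lower by a gap beyond the scatter; compound 1 lies furthest, also beyond the scatter. Compound 3 is thus the best tolerated of the measured set, with compounds 1 and 2, the two free amines, grouped below it.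

Compound 4 `O=[N+]([O-])c1ccc(/C=N/c2sc3c(c2-c2nc4ccccc4s2)CCCC3)cc1` is the next imine to be measured in this assay. The change from compound 3 is 4-nitrophenyl in place of 2,4-dichlorophenyl on a carbon with a double bond to nitrogen. The shared core and the imine linkage are kept; only the aromatic ring on the carbon with the double bond to nitrogen is exchanged.

For the measured compounds named here, no step between two measured compounds covers this kind of exchange, so there is no measured precedent in the set to lean on. The imine compound 3 sits well above the two amines, and the exchange of one aromatic ring for another on the imine carbon is taken as a modest move: the expected step of a 1.5-fold lower number from compound 3 to compound 4 (0.17 log units; within the scatter) is small, downward if anything, and not beyond the scatter. Compound 4 is accordingly expected to give about 260 ug/mL in this assay, within a range from 110 ug/mL to 600 ug/mL.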

Compound 4, half-maximal cytotoxic concentration: 454 ug/mL
Compound 4: the middle estimate sits 1.7-fold (0.24 log units) below what was measured; the measured number falls inside the stated range.
By their numbers in this assay, from the lowest: compounds 1 and 2 (each within the scatter of the next); then compounds 3 and 4 (each within the scatter of the next).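

For the compounds shown here, on a carbon with a double bond to nitrogen, 4-nitrophenyl in place of 2,4-dichlorophenyl gives a 1.2-fold higher number from compound 3 to compound 4 (0.07 log units; within the scatter) in this assay, the first step in the set that can be read at this place. The two aromatic rings differ in their make-up, with chlorine on the group that leaves and nitrogen, oxygen and hydrogen-bond acceptors on the group that enters, yet this assay does not separate compound 3 from compound 4 beyond the scatter, so this one exchange leaves the read-out unchanged within that scatter. No measurement bearing on this result is available to explain it.

From the compounds shown here alone, whether the same holds at this place for other groups stays open, such as a phenyl ring carrying a methoxy group or a carboxylic acid, or an alkyl chain in place of the aromatic ring. The free amines and the imines also differ in the chlorine on the shared core, so the contribution of the imine linkage alone to the numbers in this assay cannot be read from these compounds.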